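The source may hold more compounds than are shown below. What is called first, only, known or untested is meant among the compounds shown, and "the series" means these compounds.

Among the two compounds measured in a functional assay on K562 cells (Homo sapiens) for antiproliferative activity, read by CellTiter-Glo, with a stated time of 72 h (on this read-out higher numbers stand for an effect only at larger amounts of compound and lower numbers for an effect already at smaller amounts), compound 2, `CC(C)(C)CCNc1ncnc2c1ncn2[C@@H]1O[C@H](COS(N)(=O)=O)[C@@H](O)[C@H]1O`, stands highest with 929 nM. Its nearest neighbour, compound 1, `CCCCCCCNc1ncnc2c1ncn2[C@@H]1O[C@H](COS(N)(=O)=O)[C@@H](O)[C@H]1O`, gives 132 nM. Going by the values given here, these two differ in one place, and the step of a 7.0-fold higher number from compound 1 to compound 2 (0.85 log units; beyond the scatter) is the only measured step in the set. Compound 3, `NS(=O)(=O)OC[C@H]1O[C@@H](n2cnc3c(NCc4cccs4)ncnc32)[C@H](O)[C@@H]1O`, has not yet been measured in this assay. It differs from compound 2 as follows: thiophen-2-yl in place of neopentyl on a saturated chain carbon bound to a nitrogen on an aromatic ring. Among the compounds with values here, no measured step covers an exchange of neopentyl for thiophen-2-yl, so the only guide is the step from compound 1 to compound 2, in which the more branched chain carried the higher number. Because compound 2 with its branched chain stands at 929 nM while compound 1 stands at 132 nM, removing that branching is expected to give a step of a 3.1-fold lower number from compound 2 to compound 3 (0.49 log units; beyond the scatter). Compound 3 is therefore estimated at 300 nM, with a range from 80 nM to 1200 nM.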

Compound 3, half-maximal effective concentration: 114 nM
For compound 3 the middle estimate is 2.6-fold (0.42 log units) above the measured one; low and high end bracket the measured number.
By their numbers in this assay, from the lowest: compounds 3 and 1 (each within the scatter of the next); then compound 2.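

In this assay, the place on a saturated chain carbon bound to a nitrogen on an aromatic ring proves able to carry an aromatic ring as well as an open chain: thiophen-2-yl in place of neopentyl gives an 8.1-fold lower number from compound 2 to compound 3 (0.91 log units; beyond the scatter), a step about as large as the one that separated the two chains. Thiophen-2-yl in place of hexyl gives a 1.2-fold lower number from compound 1 to compound 3 (0.06 log units; within the scatter), so the ring and the straight chain cannot be told apart here. Among these three compounds, only compound 2, with its neopentyl group, stands apart.

Going by these compounds, it remains open whether a phenyl or furan-2-yl ring would match thiophen-2-yl at this place, and whether a chain ending in an amine or a carboxylic acid would be accepted. Nothing available explains these steps.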